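This account rests on a few compounds, and the source may have more. Where it says the series, first, only, none or still open, it means among the compounds named here.

Compound 1 `OCCCCNCc1nc2c(OCC3CCCCC3)cccc2[nH]1` gives 44.3% in an assay on cells for inhibition of interleukin-5 receptor subunit alpha (Mus musculus), read by WST assay, with a stated time of 48 h, tested at 30 uM, in the presence of a further agent that is not named here (on this read-out higher numbers stand for more inhibition at the one concentration tested (going by the name of the read-out) and lower numbers for less inhibition), and stands lowest of the two measured numbers. Compound 2 `CCC(CO)NCc1nc2c(OCC3CCCCC3)cccc2[nH]1` gives 94.3%, so the step of a number 50 percentage points higher from compound 1 to compound 2 (beyond the scatter) is large; it came from 1-(hydroxymethyl)propyl in place of 4-hydroxybutyl on an amine nitrogen. Compound 3 `c1ccc(NCc2nc3c(OCC4CCCCC4)cccc3[nH]2)cc1` has not yet been measured. It differs from compound 1 by phenyl in place of 4-hydroxybutyl on an amine nitrogen. Among the compounds with values here, no measured step exchanges the 4-hydroxybutyl for a phenyl, so the only bearing step is the one from compound 1 to compound 2, which altered the substituent on the same amine nitrogen and moved the read-out far beyond the scatter. Because a number 50 percentage points higher from compound 1 to compound 2 (beyond the scatter) shows this position can shift the number greatly, compound 3 is expected to rise above compound 1 as well, though with wide uncertainty. Compound 3 is therefore estimated at 65%, within 35% to 95%, a step of a number 20.7 percentage points higher from compound 1 to compound 3 (beyond the scatter).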

Compound 3, a percentage reported as inhibition, at one concentration (the size of the read-out at that concentration, not a potency): 25%
The estimate for compound 3 lay 40 percentage points above the measured number, outside the stated range (below it).
By their numbers in this assay, from the lowest: compound 3; then compound 1; then compound 2.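

In this assay the group on the amine nitrogen can pull the number down as well as up: the phenyl gives a number 19.3 percentage points lower from compound 1 to compound 3 (beyond the scatter) and, against the branched group, a number 69.3 percentage points lower from compound 2 to compound 3 (beyond the scatter). The loss from the branched group is thus far larger than the loss from the straight 4-hydroxybutyl chain, and the three compounds span a wide range through this one substituent alone. The change to phenyl removes the hydroxyl and brings in an aromatic ring in a single step, so the two cannot be told apart here, and no measurement available speaks to why the number fell.

As far as these compounds go, it remains open whether a plain butyl chain on this nitrogen would stay near compound 1 or sink towards compound 3. A cyclohexyl or benzyl group there would show whether the ring itself, or its direct attachment to the nitrogen, goes with the lower number.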